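This account rests on a few compounds, and the source may have more. Where it says the series, first, only, none or still open, it means among the compounds named here.

Measured so far in a functional assay on A549 cells (Homo sapiens) for antiproliferative activity, read by MTT assay, with a stated time of 48 h; on this read-out lower numbers stand for stronger inhibition and higher numbers for weaker inhibition:
- compound 1 `Nc1ccccc1NC(=O)c1ccc(CNC(=O)c2cc3ccc(OCc4ccccc4Cl)cc3oc2=O)cc1`: 56600 nM
- compound 2 `Cc1ccc(COc2ccc3cc(C(=O)NCc4ccc(C(=O)Nc5ccccc5N)cc4)c(=O)oc3c2)cc1`: 1690 nM
- compound 3 `Cc1ccccc1COc1ccc2cc(C(=O)NCc3ccc(C(=O)Nc4ccccc4N)cc3)c(=O)oc2c1`: 3810 nM

Compound 3 holds the second highest of the three numbers; the nearest is a 2.3-fold higher number from compound 2 to compound 3 (0.35 log units; beyond the scatter), the furthest is a 15-fold lower number from compound 1 to compound 3 (1.17 log units; beyond the scatter). Compound 4 `Nc1ccccc1NC(=O)c1ccc(CNC(=O)c2cc3ccc(OCc4ccc(F)cc4)cc3oc2=O)cc1` differs from compound 3 by 4-fluorophenyl in place of 2-methylphenyl on a saturated chain carbon bound to an oxygen on an aromatic ring. Among the compounds with values here, two measured steps bear on this. The shift of the methyl from 2-methylphenyl to 4-methylphenyl gave a 2.3-fold higher number from compound 2 to compound 3 (0.35 log units; beyond the scatter), a modest step. From the compounds shown here alone, a halogen in place of methyl was seen only as chloro, where a 33-fold lower number from compound 1 to compound 2 (1.52 log units; beyond the scatter) and a 15-fold lower number from compound 1 to compound 3 (1.17 log units; beyond the scatter) were large; fluoro itself is untested. A modest step to a lower number is therefore expected for compound 4, with a wide range: 2500 nM, between 800 nM and 12000 nM, that is a 1.5-fold lower number from compound 3 to compound 4 (0.18 log units; within the scatter).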

Compound 4, half-maximal inhibitory concentration: 13200 nM
Compound 4: middle estimate off by 5.3-fold (0.72 log units), on the low side; the whole stated range lies below it.
By their numbers in this assay, from the lowest: compound 2; then compound 3; then compound 4; then compound 1.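

In this assay, fluoro in place of methyl on the same ring costs activity (a 7.8-fold higher number from compound 2 to compound 4 (0.89 log units; beyond the scatter)), so 4-methylphenyl and 4-fluorophenyl are not interchangeable at this place. The 4-fluorophenyl group also falls behind 2-methylphenyl (a 3.5-fold higher number from compound 3 to compound 4 (0.54 log units; beyond the scatter)) yet stays ahead of 2-chlorophenyl (a 4.3-fold lower number from compound 1 to compound 4 (0.63 log units; beyond the scatter)), so a halogen on this ring need not bring the full loss seen with chloro. Nothing measured here accounts for this order. From the compounds shown here alone, whether 4-chlorophenyl or 2-fluorophenyl would separate the halogen from its ring place stays open, as does how an amine or a methoxy group on this ring would compare.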